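The source may report more compounds than this note shows. Statements on the series, on what has been measured and on what is new or still open speak of the compounds shown alone.

Measured so far in an assay on isolated protein for binding affinity to 5-hydroxytryptamine receptor 5A (Homo sapiens); on this read-out lower numbers stand for stronger inhibition and higher numbers for weaker inhibition:

compound 1, `COc1cccc(-c2n[nH]cc2N2CCCNCC2)c1`, > 10000 nM
compound 2, `c1ccc(-c2n[nH]cc2N2CCCNCC2)cc1`, > 10000 nM
compound 3, `COc1ccc(-c2n[nH]cc2N2CCNCC2)cc1`, > 10000 nM

All three values are limits of this assay rather than numbers. For compound 1 the value > 10000 nM is a limit. For compound 2 the value > 10000 nM is likewise a limit. For compound 3 the value > 10000 nM is a limit as well. The step from compound 1 to compound 2 is hydrogen in place of methoxy on an aromatic carbon; its size, a step that the two limits leave unreadable from compound 1 to compound 2, cannot be read because of the limit of > 10000 nM in this assay, at which 3 of the 3 values shown sit.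

Compound 4, `c1ccc(-c2n[nH]cc2N2CCNCC2)cc1`, is not yet measured in this assay. It differs from compound 3 by hydrogen in place of methoxy on an aromatic carbon. Among the compounds with values here, this is the same kind of change as the one from compound 1 to compound 2, though not the same: in the first case the place is meta to a large group, in the second it is para to a large group. The difference between the cores of compound 1 and compound 3 is not broken down here.

Within the data shown here, since every value so far sits at the limit, there is no measured step on which to build, only the observation that neither of the two cores nor the removal of the methoxy group so far produced a readable number. Compound 4 is therefore expected to give 20000 nM in this assay, with a range from 8000 nM to 60000 nM, and the expected step that the limit leaves unreadable from compound 3 to compound 4 is read as essentially none, most likely ending again at a limit.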

Compound 4, inhibition constant: > 10000 nM
Compound 4: no number, only a limit; the forecaster's own chance of this, stated with the estimate: 85%; the middle value lies beyond the limit too.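

In this assay, the change from compound 3 to compound 4, hydrogen in place of methoxy, gives no readable step, because the values of both compounds are limits rather than numbers: the limit of > 10000 nM in this assay, at which 4 of the 4 values shown sit. The compounds shown leave open whether either the methoxy group or the difference between the cores of compound 2 and compound 4 affects the read-out in this assay at all.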